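A few compounds are considered here, and "the series" means these few. Any claim that something is new, unique, unknown or untested is made for them only; others in the source may bear on it.

Compound 1 `Nc1ncnc2c1c(-c1cnc3[nH]ccc3c1)nn2CC(=O)NO` stands in a functional assay on A549 cells (Homo sapiens) for inhibition, read by MTT assay, with a stated time of 72 h (a higher number here means a weaker inhibitor, a lower number a stronger inhibitor), only as a limit: it gives > 150000 nM, which is a limit of the assay and not a number (the limit of > 150000 nM in this assay, at which 1 of the 3 values shown sits). Compound 4 `Nc1ncnc2c1c(-c1cnc3[nH]ccc3c1)nn2CCCC(=O)NO` carries the change (2-(hydroxycarbamoyl)ethyl in place of hydroxycarbamoyl on a saturated chain carbon bound to an aromatic nitrogen). Going by the values given here, one measured step bears on it. Compound 2 `Nc1nc2cc(-c3nn(CCCC(=O)NO)c4ncnc(N)c34)ccc2o1` gives > 100000 nM in this assay, again a limit of the assay rather than a number (the limit of > 100000 nM in this assay, at which 1 of the 3 values shown sits). Compound 3 `Nc1nc2cc(-c3nn(CC(=O)NO)c4ncnc(N)c34)ccc2o1` gives 27700 nM in this assay. The step of an at least 3.6-fold lower number from compound 2 to compound 3 (0.55 log units; beyond the scatter) runs in the opposite direction to the change in compound 4, so the reverse change is expected to move the number no lower and most likely to leave it at a limit. Compound 4 is therefore expected to give 200000 nM, within a range of 100000 nM to 500000 nM, corresponding to an expected step that the limit leaves unreadable from compound 1 to compound 4.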

Compound 4, half-maximal inhibitory concentration: > 150000 nM
Compound 4: no number, only a limit; the forecaster's own chance of this, stated with the estimate: 85%; the middle value is on the limit's open side.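

Going by these compounds alone, compound 1 and compound 4 both give only limits of the assay in this assay, so no step between them can be read. The compounds shown leave open whether 2-(hydroxycarbamoyl)ethyl in place of hydroxycarbamoyl changes the number at all on the core of compound 1.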